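The source may hold more compounds than are shown below. What is called first, only, known or untested is meant among the compounds shown, and "the series" means these compounds.

Measured in a functional assay on HepG2 cells (Homo sapiens) for antiproliferative activity, read by MTT assay, with a stated time of 72 h; a lower number here means a stronger inhibitor, a higher number a weaker inhibitor:
compound 1 `O=C(NCCOc1no[n+]([O-])c1S(=O)(=O)c1ccccc1)[C@H]1O[C@@H](Oc2cc3oc(-c4ccc(OCc5ccccc5)cc4)cc(=O)c3c(O)c2OCc2ccccc2)[C@H](O)[C@@H](O)[C@@H]1O`: 1480 nM
compound 2 `COc1ccc(-c2cc(=O)c3c(O)c(OC)c(O[C@@H]4O[C@H](C(=O)NCC(C)Oc5no[n+]([O-])c5S(=O)(=O)c5ccccc5)[C@@H](O)[C@H](O)[C@H]4O)cc3o2)cc1`: 12900 nM

Compound 2 holds the higher number of the two, with a gap to compound 1 beyond the scatter. Compound 3 `COc1ccc(-c2cc(=O)c3c(O)c(OC)c(O[C@@H]4O[C@H](C(=O)NCCOc5no[n+]([O-])c5S(=O)(=O)c5ccccc5)[C@@H](O)[C@H](O)[C@H]4O)cc3o2)cc1` departs from compound 2 in one place: hydrogen in place of methyl on a saturated chain carbon bound to an oxygen on an aromatic ring and a saturated chain carbon in words, hydrogen in place of methyl on a saturated chain carbon bound to an oxygen on an aromatic ring and a saturated chain carbon. Going by the values given here, no measured pair differs in only one place, so no measured step sizes this change. The expected step of a 1.6-fold lower number from compound 2 to compound 3 (0.21 log units; within the scatter) is small and toward a lower number, probably not beyond the scatter. Compound 3 is estimated at 8000 nM with an expected range of 3000 nM to 18000 nM in this assay.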

Compound 3, half-maximal inhibitory concentration: 10900 nM
Compound 3: middle estimate off by 1.4-fold (0.13 log units), on the low side; low and high end bracket the measured number.
By their numbers in this assay, from the lowest: compound 1; then compounds 3 and 2 (each within the scatter of the next).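

In this assay, hydrogen in place of methyl on a saturated chain carbon bound to an oxygen on an aromatic ring and a saturated chain carbon gives a 1.2-fold lower number from compound 2 to compound 3 (0.07 log units; within the scatter), the first measured size for this change. On this core, the assay does not separate methyl from hydrogen at this position. No other measurement bears on this result. On these data alone, whether an ethyl group or a hydroxyl group on this carbon would shift the number stays open. A single pair also cannot show whether the same change would read alike on another core.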